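A few compounds are considered here, and "the series" means these few. Any claim that something is new, unique, unknown or untested is made for them only; others in the source may bear on it.

Compound 1 `CCCCCCCCCCCCCCCCCCNC(=O)[C@@H](NC(=O)c1nccc2ccccc12)[C@@H](C)O` gives 136000 nM in a functional assay on SW-620 cells (Homo sapiens) for cytotoxicity, read by MTT assay, with a stated time of 48 h; a lower number here means a stronger inhibitor, a higher number a weaker inhibitor.
Compound 2 `CCCCCCCCCCCCCCCCCCNC(=O)[C@@H](NS(=O)(=O)c1ccc(C)cc1)[C@@H](C)O` gives 32500 nM in this assay.

Going by the values given here, compound 2 holds the lower of these two numbers, the only measured step being a 4.2-fold lower number from compound 1 to compound 2 (0.62 log units; beyond the scatter), a change at the amine nitrogen. Compound 3 `CCCCCCCCCCCCCCCCCCNC(=O)[C@@H](NS(=O)(=O)c1cccs1)[C@@H](C)O` differs from compound 2 by thiophen-2-yl in place of 4-methylphenyl on a sulfonyl sulfur. Among the compounds with values here, no measured step touches the ring on the sulfonyl sulfur, so nothing seen so far bears directly on this change, and a step no larger than the usual scatter is expected in this assay. Compound 3 is therefore estimated at 40000 nM, within 12000 nM to 120000 nM, a step of a 1.2-fold higher number from compound 2 to compound 3 (0.09 log units; within the scatter).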

Compound 3, half-maximal inhibitory concentration: > 200000 nM
Compound 3 ended at the assay's limit (the forecaster's own chance of this, stated with the estimate: 10%); middle value at least 5.0-fold (0.69 log units) away from the limit.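

The ring on the sulfonyl sulfur matters in this assay: thiophen-2-yl in place of 4-methylphenyl gives an at least 6.1-fold higher number from compound 2 to compound 3 (0.78 log units; beyond the scatter). The value of compound 3 is a limit of the assay and not a number: the limit of > 200000 nM in this assay, at which 1 of the 3 values shown sits. The comparison with the isoquinolin-1-yl amide shows an at least 1.4-fold higher number from compound 1 to compound 3 (0.16 log units; that floor lies within the scatter), so no order of those two can be claimed.

Going by these compounds, with only these two rings on the sulfonyl sulfur, it stays open whether the methyl group or the six-membered ring carries the difference. A plain phenyl group there would separate the two.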